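The source may hold more compounds than are shown below. What is called first, only, known or untested is meant among the compounds shown, and "the series" means these compounds.

Three compounds share a core, and a fourth is not yet measured. Compound 1 `COc1cc(-c2cc(/C=C/C(=O)c3ccc(N)cc3)[nH]n2)cc(OC)c1OC` gives -63% in a functional assay on ACHN cells (Homo sapiens) for cytotoxicity, read by sulforhodamine B assay, with a stated time of 48 h, tested at 100 uM; on this read-out higher numbers stand for a weaker effect at the one concentration tested and lower numbers for a stronger effect. Compound 2 `COc1ccc(C(=O)/C=C/c2cc(-c3cc(OC)c(OC)c(OC)c3)n[nH]2)cc1OC` gives -91% in this assay, the second highest of the three numbers, and compound 3 `COc1ccc(C(=O)/C=C/c2cc(-c3cc(OC)c(OC)c(OC)c3)n[nH]2)cc1` gives -93%. The steps of a number 28 percentage points lower from compound 1 to compound 2 (beyond the scatter) and a number 30 percentage points lower from compound 1 to compound 3 (beyond the scatter) lie beyond the scatter, while the step of a number 2 percentage points lower from compound 2 to compound 3 (within the scatter) lies within it. Compound 4 `COc1cc(C(=O)/C=C/c2cc(-c3cc(OC)c(OC)c(OC)c3)n[nH]2)cc(OC)c1OC` differs from compound 2 by methoxy in place of hydrogen on an aromatic carbon. The step from compound 2 to compound 3 bears most directly on this change, since it removes a methoxy from the same ring and leaves the number within the scatter; the two steps from compound 1 concern the exchange of amino for methoxy and are less directly comparable. No step beyond the scatter is therefore expected in this assay. Compound 4 is expected to give -88%, between -100% and -65%, which corresponds to an estimated step of a number 3 percentage points higher from compound 2 to compound 4 (within the scatter).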

Compound 4, a percentage reported as activity, at one concentration (the size of the read-out at that concentration, not a potency): -98%
Beside the measured number, compound 4's estimate is 10 percentage points above it; the measured number falls inside the stated range.
By their numbers in this assay, from the lowest: compounds 4, 3 and 2 (each within the scatter of the next); then compound 1.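

With methoxy in place of hydrogen on an aromatic carbon, ortho to a methoxy group and meta to a large group, this assay gives a number 7 percentage points lower from compound 2 to compound 4 (within the scatter). The earlier step, a number 2 percentage points lower from compound 2 to compound 3 (within the scatter), showed only that a methoxy could be removed from this ring without a step beyond the scatter; this one shows the same for adding a methoxy at a further place on that ring, so neither change separates these compounds in this read-out. Nothing available here gives a reason for this outcome.

The compounds shown leave open whether this place accepts anything other than hydrogen or methoxy, such as an amine, a carboxylic acid or a longer chain like ethoxy. They also leave open whether compound 2 and compound 4 would separate at other concentrations, as each was read at a single one.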